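Trimming the Amide Substituent on Compound 2

The source may hold more compounds than are shown below. What is called first, only, known or untested is meant among the compounds shown, and "the series" means these compounds.

Measured in a functional assay on Huh-7 cells (Homo sapiens) for antiproliferative activity, read by CCK-8 assay, with a stated time of 72 h; on this read-out higher numbers stand for weaker inhibition of growth and lower numbers for stronger inhibition of growth:
Compound 1 `CCNC(=O)c1ccc2c(ccn2-c2ncc3c(n2)N(c2ccn(C)n2)C(CC)C(=O)N3C)c1`: 20300 nM
Compound 2 `CCC1C(=O)N(C)c2cnc(-n3ccc4cc(C(=O)NCC(C)C)ccc43)nc2N1c1ccn(C)n1`: 5070 nM

Of these two measured compounds, compound 2 holds the lower number, at 5070 nM, and so shows the stronger inhibition of growth. The next compound, compound 3 `CCC1C(=O)N(C)c2cnc(-n3ccc4cc(C(N)=O)ccc43)nc2N1c1ccn(C)n1`, keeps the shared core but has hydrogen in place of isobutyl on an amide-type nitrogen, so that isobutylcarbamoyl becomes carbamoyl: hydrogen in place of isobutyl on an amide-type nitrogen.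

Among the measured compounds shown here, only one measured step bears on this change. It concerns the group on the same amide-type nitrogen, and the number fell with the larger group: a 4.0-fold lower number from compound 1 to compound 2 (0.60 log units; beyond the scatter). For the measured compounds named here, this modest step lies beyond the scatter, but a single step cannot establish a trend, and no measured compound carries hydrogen at this place. Removing the whole isobutyl group is therefore expected to reverse that gain, at least roughly, and the expected change in this assay is a 3.0-fold higher number from compound 2 to compound 3 (0.47 log units; beyond the scatter). For compound 3 the estimated value is 15000 nM, with an expected range from 4000 nM to 50000 nM.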

Compound 3, concentration for 50% growth inhibition: "not active" (no number reported)
No number was reported for compound 3, so the estimate cannot be set against anything.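

In this assay, among the compounds shown here, compound 3 is recorded only as "not active", with no number reported, so no step from compound 2 to compound 3 can be read. Nothing shown accounts for this result. The compounds shown leave open how far the amide substituent governs growth inhibition beyond the single step from ethyl to isobutyl.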